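The source may hold more compounds than are shown below. What is called first, only, known or untested is meant among the compounds shown, and "the series" means these compounds.

Compound 1, `Cc1ccc(NC(=S)NC(=O)c2cn(-c3ccccc3)nc2-c2ccc(F)cc2)cc1`, was tested in a functional assay on A549 cells (Homo sapiens) for inhibition, read by CCK-8 assay, with a stated time of 48 h (on this read-out higher numbers stand for weaker inhibition and lower numbers for stronger inhibition), where compound 1 gives 2080 nM. Within the data shown here, its only measured companion is compound 2, `O=C(NC(=S)Nc1ccc(F)cc1)c1cn(-c2ccccc2)nc1-c1ccc(F)cc1`, which in this assay gives 3540 nM. The two differ in one place, fluoro in place of methyl on an aromatic carbon, and the step of a 1.7-fold higher number from compound 1 to compound 2 (0.23 log units; within the scatter) lies within the scatter, so compound 1 stands as one of two compounds whose numbers cannot be told apart.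

Compound 3, `COc1ccc(-c2nn(-c3ccccc3)cc2C(=O)NC(=S)Nc2ccc(C)cc2)cc1`, is not yet measured. It differs from compound 1 by methoxy in place of fluoro on an aromatic carbon: the fluorine on the aromatic ring attached to the shared core gives way to a methoxy group. Among the measured compounds shown here, no measured step touches that ring; the single known step, a 1.7-fold higher number from compound 1 to compound 2 (0.23 log units; within the scatter), sits on the other aromatic ring and shows that swapping one small group for another there leaves the number within the scatter. With nothing more to go on, the expectation for compound 3 is an unchanged number, the step of a 1.2-fold higher number from compound 1 to compound 3 (0.08 log units; within the scatter) being the estimate. Compound 3 is therefore expected to give about 2500 nM, with a range from 900 nM to 7000 nM.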

Compound 3, half-maximal inhibitory concentration: 1250 nM
The estimate for compound 3 lay 2.0-fold (0.30 log units) above the measured number; measured number inside the range.
By their numbers in this assay, from the lowest: compounds 3, 1 and 2 (each within the scatter of the next, the first and the last beyond it).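

In this assay, among these compounds, the change from 4-fluorophenyl to 4-methoxyphenyl gives a 1.7-fold lower number from compound 1 to compound 3 (0.22 log units; within the scatter) and is the first measured step on this ring. The entering methoxy group counts two heavy atoms against one for fluoro and adds a hydrogen-bond acceptor, yet at this position, para to a large group, the number stays within the usual scatter. Together with the earlier step on the other aromatic ring, this means that each of the two single changes measured so far leaves the number within the scatter, and no compound shown goes against that. Nothing at hand explains why this exchange leaves the number within the scatter.

From the compounds shown here alone, whether a carboxylic acid, an amine or a longer chain such as butoxy in this same place would carry the number beyond the scatter remains open. Also open, going by these compounds, is how the methoxy group would read with fluoro in place of the methyl on the other aromatic ring, a pairing that would connect this change directly to compound 2.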